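The compounds below may be only part of what the source reports. "The series", "measured", "known", "first", "only" and "open" are said of these compounds alone.

In a functional assay on HeLa cells (Homo sapiens) for inhibition, read by CCK-8 assay, with a stated time of 48 h (on this read-out lower numbers stand for stronger inhibition and higher numbers for weaker inhibition), compound 1 `O=S(=O)(NCCNC(=S)Nc1cccc(Cl)c1)c1ccc(-c2ccccc2OCc2cccc(O)c2)s1` gives 10700 nM and compound 2 `O=S(=O)(NCCNC(=S)Nc1cccc(Cl)c1)c1ccc(-c2ccccc2OCc2ccccc2)s1` gives 8400 nM. Among the measured compounds shown here, these are the only two exact numbers so far, and compound 2 sits level with compound 1, since the step is a 1.3-fold lower number from compound 1 to compound 2 (0.11 log units; within the scatter). For compound 3 `COc1cccc(NC(=S)NCCNS(=O)(=O)c2ccc(-c3ccccc3Oc3ccc([N+](=O)[O-])cc3)s2)c1` the assay reports only a limit, > 50000 nM.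

Compound 4 `Cc1cc(C)cc(NC(=O)NCCNS(=O)(=O)c2ccc(-c3ccccc3OCc3ccccc3)s2)c1` has not yet been measured. It departs from compound 2 in one place: a group of 11 heavy atoms (9 carbon, 1 nitrogen, 1 oxygen; one six-membered aromatic ring of carbon only) in place of a group of 10 heavy atoms (7 carbon, 1 nitrogen, 1 sulfur, 1 chlorine; one six-membered aromatic ring of carbon only), on an amine nitrogen. The group that enters is (3,5-dimethylphenyl)carbamoyl, on an amine nitrogen.

For the measured compounds named here, the one measured step, a 1.3-fold lower number from compound 1 to compound 2 (0.11 log units; within the scatter), swaps hydroxy for hydrogen on an aromatic carbon and leaves this group untouched, so no measurement tests the change directly. Compound 3 also differs on this nitrogen, though not only there, and the limit of > 50000 nM in this assay, at which 1 of the 3 values shown sits, tilts the expectation toward weaker inhibition in this assay. The expected change is modest, a 2.4-fold higher number from compound 2 to compound 4 (0.38 log units; beyond the scatter), and remains uncertain. Compound 4 is therefore estimated at 20000 nM, with an expected range from 6000 nM to 50000 nM.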

Compound 4, half-maximal inhibitory concentration: > 50000 nM
Compound 4 was reported as a limit; the forecaster's own chance of this, stated with the estimate: 20%; middle value at least 2.5-fold (0.39 log units) away from the limit.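

Among the compounds shown here, this step is the first direct test of the group on this amine nitrogen: (3,5-dimethylphenyl)carbamoyl in place of the group holding sulfur and chlorine gives an at least 5.9-fold higher number from compound 2 to compound 4 (0.77 log units; beyond the scatter), so in this assay this position does not accept every change of this size. Compound 4 gives > 50000 nM, which is a limit and not a number, so the step has a lower bound and no exact size. Compound 4 now shares this limit with compound 3, which also differs on this nitrogen, though not only there: the limit of > 50000 nM in this assay, at which 2 of the 4 values shown sit.

Still open, as far as these compounds go, is which part of the swap matters, the oxygen for the sulfur or the two methyl groups for the chlorine; a (3-chlorophenyl)carbamoyl group on this nitrogen would separate them. Also open, from the compounds shown here alone, is how an acetyl group on this nitrogen would behave in this assay.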